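Chloro Substitution on the Sulfonyl Aryl Ring of Aortic Antagonists

The compounds below may be only part of what the source reports. "The series", "measured", "known", "first", "only" and "open" are said of these compounds alone.

The study compares four compounds that share one core and differ in the linker and in a single aromatic substituent. Compound 1 `CC(C)c1ccc2c(CCCS(=O)(=O)Nc3ccccc3)cc(S(=O)(=O)O)c-2cc1` and compound 2 `CC(C)c1ccc2c(CCCS(=O)(=O)Nc3ccc(Cl)cc3)cc(S(=O)(=O)O)c-2cc1` carry a sulfonamide linker, while compound 3 `CC(C)c1ccc2c(CCCC(=O)NS(=O)(=O)c3ccccc3)cc(S(=O)(=O)O)c-2cc1` and compound 4 `CC(C)c1ccc2c(CCCC(=O)NS(=O)(=O)c3ccc(Cl)cc3)cc(S(=O)(=O)O)c-2cc1` carry an acylsulfonamide linker. In a functional assay on thoracic aorta for antagonist activity at thromboxane A2 receptor (Rattus norvegicus) (a lower number here means a stronger inhibitor, a higher number a weaker inhibitor), compound 1 gives 8700 nM, compound 2 gives 860 nM, and compound 3 gives 65000 nM. The change from compound 1 to compound 2 is chloro in place of hydrogen on an aromatic carbon and produced a 10-fold lower number from compound 1 to compound 2 (1.01 log units; beyond the scatter). How the core of compound 3 differs from that of compound 1 is not broken down here; their values show that compound 3 stands higher in this assay. Compound 4 arises from compound 3 by the same change, (chloro in place of hydrogen on an aromatic carbon). Compound 4 has not yet been measured in this assay. Because the earlier change gave a 10-fold lower number from compound 1 to compound 2 (1.01 log units; beyond the scatter), a step of similar size is expected from compound 3 to compound 4, namely a 9.3-fold lower number from compound 3 to compound 4 (0.97 log units; beyond the scatter). Compound 4 is therefore estimated at 7000 nM, within a range from 2500 nM to 25000 nM.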

Compound 4, half-maximal inhibitory concentration: 54000 nM
Estimate against measurement, compound 4: 7.7-fold (0.89 log units) below; measured number above the stated range.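

In this assay, among the compounds shown here, chloro in place of hydrogen on the acylsulfonamide linker gave a 1.2-fold lower number from compound 3 to compound 4 (0.08 log units; within the scatter) and so left no step that stands out from the scatter. The clear step seen with the sulfonamide linker thus did not carry over to the acylsulfonamide linker, and the two steps disagree: the same change on two cores in this assay, a 10-fold lower number (1.01 log units; beyond the scatter) from compound 1 to compound 2 and a 1.2-fold lower number (0.08 log units; within the scatter) from compound 3 to compound 4, 8.4-fold (0.92 log units) apart, beyond the scatter of two such steps. This shows that, across these two pairs, the step measured on one core cannot be relied on for the other, but it does not show which feature of the linker accounts for the difference, and two pairs give no rule for any further core.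

The compounds shown leave open how the same change behaves with other linkers, such as a longer chain or a carboxylic acid in place of the acylsulfonamide, and whether fluoro or methoxy on the same ring would repeat either step. They also leave open whether the contrast between the two cores holds anywhere outside this assay as well.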